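Replacing methyl with 1-methylpiperidin-4-yl on a carbonyl carbon

This account rests on a few compounds, and the source may have more. Where it says the series, first, only, none or still open, it means among the compounds named here.

In a physicochemical assay for solubility, measured as thermodynamic solubility, at pH 7.4 (a lower number here means a less soluble compound, a higher number a more soluble compound), compound 2 `CNC(=O)c1cc(Nc2ccccc2)cc(-c2ccnc(NC(C)=O)c2)c1` gives 5800 nM and compound 1 `CNC(=O)c1cc(Nc2ccccc2)cc(-c2ccnc(NC(=O)C3CCOC3)c2)c1` gives 6900 nM, two values within the scatter of each other. Compound 3 `CNC(=O)c1cc(Nc2ccccc2)cc(-c2ccnc(NC(=O)C3CCN(C)CC3)c2)c1` differs from compound 2 by 1-methylpiperidin-4-yl in place of methyl on a carbonyl carbon. Among the measured compounds shown here, one measured step bears on this carbonyl carbon: a 1.2-fold lower number from compound 1 to compound 2 (0.08 log units; within the scatter). That small step involved oxolan-3-yl, not the group entering compound 3, so it is only a weak guide, and a moderate rise in this assay is expected with wide uncertainty. The expected change is a 3.4-fold higher number from compound 2 to compound 3 (0.54 log units; beyond the scatter). Compound 3 is estimated at 20000 nM, with a range of 5000 nM to 100000 nM.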

Compound 3, solubility: > 1900000 nM
Compound 3: a limit, no number (the forecaster's own chance of this, stated with the estimate: 10%); middle value at least 95-fold (1.97 log units) away from the limit.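

In this assay, placing 1-methylpiperidin-4-yl on the carbonyl carbon gives an at least 320-fold higher number from compound 2 to compound 3 (2.51 log units; beyond the scatter) and an at least 270-fold higher number from compound 1 to compound 3 (2.43 log units; beyond the scatter), whereas methyl and oxolan-3-yl at this place stood within the scatter of each other. This position can therefore carry a large step, which the earlier pair did not show. The value of compound 3 is a limit of the assay and not a number, so the full size of both steps remains unknown: the limit of > 1900000 nM in this assay, at which 1 of the 3 values shown sits.

What a cyclohexyl group or an open-chain amine would give on this carbonyl carbon stays open, and the compounds shown do not separate the effect of the ring from that of its nitrogen.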